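The compounds below may be only part of what the source reports. "The series", "measured", "known", "first", "only" and "open" are said of these compounds alone.

Compound 1 `COc1ccccc1Cn1cc[nH]c1=S`: 74100 nM
Compound 2 `S=c1[nH]ccn1Cc1ccccc1Cl`: 355000 nM

In an assay on isolated protein for inhibition of Dopamine beta-hydroxylase (Rattus norvegicus) (on this read-out lower numbers stand for stronger inhibition and higher numbers for weaker inhibition), compound 2 gives the weaker result of the two; compound 1 sits a good deal lower, as the step of a 4.8-fold higher number from compound 1 to compound 2 (0.68 log units; beyond the scatter) shows. Compound 3 `Cc1ccccc1Cn1cc[nH]c1=S` is not yet measured; it differs from compound 2 by methyl in place of chloro on an aromatic carbon. For the measured compounds named here, no measured step swaps methyl for chloro, so only the single step from compound 1 to compound 2 bears on it, and only loosely. Compound 3 is therefore expected to land near compound 2, with a step of a 1.8-fold lower number from compound 2 to compound 3 (0.25 log units; within the scatter), so an estimate of 200000 nM with a range from 60000 nM to 600000 nM.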

Compound 3, half-maximal inhibitory concentration: 339000 nM
For compound 3 the middle estimate is 1.7-fold (0.23 log units) below the measured one, within the range that was stated.
By their numbers in this assay, from the lowest: compound 1; then compounds 3 and 2 (each within the scatter of the next).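

In this assay, swapping chloro for methyl on this aromatic carbon leaves the result unchanged, with a 1.0-fold lower number from compound 2 to compound 3 (0.02 log units; within the scatter), so these two groups cannot be told apart here. Methoxy stands apart from methyl as well as from chloro, with a 4.6-fold higher number from compound 1 to compound 3 (0.66 log units; beyond the scatter), so the gap seen earlier is not specific to chloro. No measured evidence here accounts for this result.

Going by these compounds, it remains open whether a hydroxyl, an ethoxy or an amine on this aromatic carbon would give a number like that of compound 1 or like those of compound 2 and compound 3. On these data alone, whether any group here can go lower than methoxy also remains unknown.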